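A Methoxy for a Methylsulfanyl: What to Expect

A few compounds are considered here, and "the series" means these few. Any claim that something is new, unique, unknown or untested is made for them only; others in the source may bear on it.

For the measured compounds named here, compound 1 `CSc1ccc(CNc2nc(SC)nc3ncccc23)cc1` is the stronger of the two compounds measured so far. In a functional assay on MCF7 cells (Homo sapiens) for cytotoxicity, read by MTT assay, with a stated time of 72 h (a higher number here means a weaker inhibitor of growth, a lower number a stronger inhibitor of growth), compound 1 gives 50 nM. Compound 2 `C[Se]c1nc(N)c2ccccc2n1`, built on a different core, gives 46500 nM in this assay, a far higher number and beyond the scatter, so compound 1 stands as the stronger inhibitor of growth of the pair. Compound 3 `COc1ccc(CNc2nc(SC)nc3ncccc23)cc1` has not yet been measured. It differs from compound 1 in one place: methoxy in place of methylsulfanyl on an aromatic carbon. Going by the values given here, no measured pair shows this change, so its effect cannot be read from these data. Because compound 1 gives 50 nM, compound 3 is expected to stay near it, with at most a modest weakening. The step of a 2.0-fold higher number from compound 1 to compound 3 (0.30 log units; within the scatter) is expected to be small, likely within the scatter. Compound 3 is estimated at 100 nM, within 25 nM to 400 nM.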

Compound 3, concentration for 50% growth inhibition: 48100 nM
Beside the measured number, compound 3's estimate is 480-fold (2.68 log units) below it; the whole stated range lies below it.
By their numbers in this assay, from the lowest: compound 1; then compounds 2 and 3 (each within the scatter of the next).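

In this assay, for the compounds shown here, the exchange of methylsulfanyl for methoxy on this aromatic carbon brings a 960-fold higher number from compound 1 to compound 3 (2.98 log units; beyond the scatter) and so shows that the position is highly sensitive to which group it carries, something the earlier compounds, built on different cores, could not show. The two groups match in their counts of heavy atoms, hydrogen-bond donors and acceptors and differ only in sulfur against oxygen, so those counts alone do not foretell the outcome at this position. The data shown offer no measurement that explains the step.

On these data alone, how an amine or a longer sulfur chain such as ethylsulfanyl would fare at this carbon remains open. It therefore stays unclear whether methylsulfanyl is unusually favourable here or methoxy is unusually poor.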